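Series notes: replacing the carboxy group on the chain

The compounds below may be only part of what the source reports. "The series", "measured", "known", "first", "only" and "open" are said of these compounds alone.

The shared core carries a side chain whose end group is varied. Compound 1 `Cc1c(C)c2c(c(C)c1O)CC[C@](C)(CC(=O)[N-][N+](C)(C)C)O2` gives 8000 nM in a functional assay (brain) for inhibition, with Rattus norvegicus as the target; on this read-out higher numbers stand for weaker inhibition and lower numbers for stronger inhibition. Among the compounds with values here, compound 2 `Cc1c(C)c2c(c(C)c1O)CC[C@](C)(CC(=O)O)O2` gives 14000 nM in this assay; the one measured step, a 1.8-fold higher number from compound 1 to compound 2 (0.24 log units; within the scatter), lies within the scatter. Compound 2 thus stands at the higher of the two numbers, but compound 1 sits within the scatter of it, so no order between the two can be claimed.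

Compound 3 `Cc1c(C)c2c(c(C)c1O)CC[C@](C)(CC[N+](C)(C)C)O2` is not yet measured. Relative to compound 2 the change is a group of 5 heavy atoms (4 carbon, 1 nitrogen; no ring) in place of a group of 3 heavy atoms (1 carbon, 2 oxygen; no ring), on a saturated chain carbon bound to a saturated ring carbon. Within the data shown here, no measured step bears directly on this change: the only step seen, a 1.8-fold higher number from compound 1 to compound 2 (0.24 log units; within the scatter), concerns the group on the carbonyl carbon, and in compound 3 the carboxy group is gone altogether. Among the measured compounds shown here, that step showed one exchange of chain end for another leaving the number within the scatter, and this is the only guide. Compound 3 is therefore expected to give a number close to those seen so far, the estimated step being a 1.4-fold lower number from compound 2 to compound 3 (0.15 log units; within the scatter). For compound 3 the estimate in this assay is 10000 nM, with a range from 3000 nM to 40000 nM.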

Compound 3, half-maximal inhibitory concentration: 2200 nM
Beside the measured number, compound 3's estimate is 4.5-fold (0.66 log units) above it; measured number below the stated range.
By their numbers in this assay, from the lowest: compound 3; then compounds 1 and 2 (each within the scatter of the next).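

In this assay, within the data shown here, the chain end on a saturated chain carbon bound to a saturated ring carbon proves able to shift the number: putting the group of 5 heavy atoms (net charge +1, 0 hydrogen-bond donors, 0 hydrogen-bond acceptors) in place of carboxy gives a 6.4-fold lower number from compound 2 to compound 3 (0.80 log units; beyond the scatter), the first step beyond the scatter. The same group in place of the other measured chain end gives a 3.6-fold lower number from compound 1 to compound 3 (0.56 log units; beyond the scatter), so compound 3 now has the lowest number of the three, while compounds 1 and 2 remain within the scatter of each other. No measurement at hand accounts for either step.

This exchange removes the carboxy group and introduces the net charge in a single change, so the compounds shown do not separate the two contributions to the lower number. Also open, going by these compounds, is how a tertiary amine or an all-carbon tert-butyl group at this place, or a longer chain ending in the same group of 5 heavy atoms, would compare with compound 3 .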